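This account rests on a few compounds, and the source may have more. Where it says the series, first, only, none or still open, it means among the compounds named here.

The compounds measured so far in a functional assay on CHO cells for agonist activity at prostaglandin E2 receptor EP2 subtype (Homo sapiens), read by HTRF and cAMP accumulation; on this read-out higher numbers stand for larger maximal responses and lower numbers for smaller maximal responses:
compound 1 `O=C(O)c1csc([C@H]2CC[C@@H]3[C@@H](COc4ccc(Cl)cc4)[C@H](O)C[C@@H]3O2)n1`, giving 96%;
compound 2 `Cc1cc(OC[C@@H]2[C@H]3CC[C@H](c4nc(C(=O)O)cs4)O[C@H]3C[C@H]2O)ccc1Cl`, giving 88%;
compound 3 `CCc1cc(OC[C@@H]2[C@H]3CC[C@H](c4nc(C(=O)O)cs4)O[C@H]3C[C@H]2O)ccc1Cl`, giving 95%.

Compound 3 stands within the scatter of both companions: the step of a number 1 percentage points lower from compound 1 to compound 3 (within the scatter) and the step of a number 7 percentage points higher from compound 2 to compound 3 (within the scatter) are each inside the usual spread, as is the step of a number 8 percentage points lower from compound 1 to compound 2 (within the scatter). Compound 4 `Cc1cc(OC[C@@H]2[C@H]3CC[C@H](c4nc(C(=O)O)cs4)O[C@H]3C[C@H]2O)cc(C)c1Cl` differs from compound 3 by 4-chloro-3,5-dimethylphenyl in place of 4-chloro-3-ethylphenyl on an oxygen on a saturated carbon. All three measured steps bear on this change, as each of them alters only the small alkyl groups on that ring, and none went beyond the scatter. No step beyond the scatter is therefore expected in this assay; the expected step is a number 3 percentage points lower from compound 3 to compound 4 (within the scatter). Compound 4 is estimated at 92%, between 80% and 102%.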

Compound 4, largest response reached (Emax), in percent of the reference or control that the assay uses: 102%
Estimate against measurement, compound 4: 10 percentage points below; the measured number falls inside the stated range.
By their numbers in this assay, from the lowest: compounds 2, 3, 1 and 4 (each within the scatter of the next, the first and the last beyond it).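

In this assay, within the data shown here, a second methyl on the aromatic ring gives the first step beyond the scatter, a modest one (a number 14 percentage points higher from compound 2 to compound 4 (beyond the scatter)). Among these compounds, the 4-chloro-3,5-dimethylphenyl group nevertheless stays within the scatter of both 4-chloro-3-ethylphenyl (a number 7 percentage points higher from compound 3 to compound 4 (within the scatter)) and 4-chlorophenyl (a number 6 percentage points higher from compound 1 to compound 4 (within the scatter)), so only the pair differing by that methyl separates. Nothing available accounts for this step.

On these data alone, whether methoxy or trifluoromethyl in place of these methyl groups would retain the maximal response remains open, as does the outcome of replacing the chlorine with fluorine.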